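The compounds below may be only part of what the source reports. "The series", "measured", "known", "first", "only" and "open" are said of these compounds alone.

Measured so far:

- Compound 1 `Nc1cc(-c2ccc3c(N)n[nH]c3c2)nc(N)n1` — 58000 nM
- Compound 2 `Nc1cc(-c2ccc3c(N)n[nH]c3c2)ncn1` — 5000 nM
- Compound 3 `CC(C)(C)Oc1cc(-c2ccnc(N)n2)cc2[nH]nc(N)c12` — 68000 nM

All three numbers come from a physicochemical assay for solubility, read by LC-MS, in phosphate buffer, measured as kinetic solubility, with a stated time of 24 h, at 25 degrees C, at pH 7.4; on this read-out higher numbers stand for higher solubility and lower numbers for lower solubility. Compound 3 gives the highest of the three values, but its gap to compound 1 is within the scatter, so the two cannot be ranked against each other; only compound 2 stands clearly apart, with a lower value. Within the data shown here, the one single-point step recorded, a 12-fold lower number from compound 1 to compound 2 (1.06 log units; beyond the scatter), concerns a change on an aromatic carbon and does not touch the part of the molecule changed here.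

Compound 4 `Nc1nccc(-c2cc(OC3CCCOC3)c3c(N)n[nH]c3c2)n1` differs from compound 3 in one place: oxan-3-yl in place of tert-butyl on an oxygen on an aromatic ring. Among the measured compounds shown here, no measured pair shows this kind of exchange, so there is no step to lean on directly. The change replaces a small branched group with a ring that carries one more hydrogen-bond acceptor; with nothing in the data to point the other way, the expectation is a step of about a 1.2-fold higher number from compound 3 to compound 4 (0.07 log units; within the scatter), which is within the scatter. Compound 4 is therefore expected to give around 80000 nM in this assay, with a likely range from 30000 nM to 200000 nM.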

Compound 4, solubility: 1000000 nM
Compound 4: middle estimate off by 13-fold (1.10 log units), on the low side, outside the stated range (above it).
By their numbers in this assay, from the lowest: compound 2; then compounds 1 and 3 (each within the scatter of the next); then compound 4.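

The group on this oxygen on an aromatic ring has a large bearing on the read-out in this assay: exchanging tert-butyl for oxan-3-yl gives a 15-fold higher number from compound 3 to compound 4 (1.17 log units; beyond the scatter), the first step seen at this place. This single exchange alters several things at once, bringing in a six-membered non-aromatic ring, an oxygen atom, a hydrogen-bond acceptor and more heavy atoms, and this one pair cannot separate their contributions. No measurement available here accounts for the size of this step.

On these data alone, it remains open whether the ring oxygen matters at all, a question that a cyclohexyl group on the same oxygen would address. Also unresolved is how the result would change with oxan-4-yl, an open methoxyethyl chain or a ring carrying an amine, such as piperidin-4-yl.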